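Moving a bromine on the amide-side ring of compound 1

The source may report more compounds than this note shows. Statements on the series, on what has been measured and on what is new or still open speak of the compounds shown alone.

Measured compounds:
- compound 1, `CCc1ccc(NC(=O)c2csc(Cc3c(Cl)cccc3Cl)n2)cc1`: 810 nM
- compound 2, `O=C(Nc1ccc(Br)cc1)c1csc(Cc2c(Cl)cccc2Cl)n1`: 400 nM
- compound 3, `O=C(Nc1ccc(C(F)(F)F)nc1)c1csc(Cc2c(Cl)cccc2Cl)n1`: 110 nM

In an assay on CHO cells, read by calcium flux (a lower number here means a stronger inhibitor, a higher number a weaker inhibitor), compound 1 gives the highest of the three numbers; compound 2 sits nearest, and compound 3 is furthest from it. The unmeasured compound 4, `O=C(Nc1cccc(Br)c1)c1csc(Cc2c(Cl)cccc2Cl)n1`, differs from compound 1 by 3-bromophenyl in place of 4-ethylphenyl on an amide-type nitrogen. Going by the values given here, one measured step bears on this: a 2.0-fold lower number from compound 1 to compound 2 (0.31 log units; beyond the scatter), which exchanged the same two groups but kept the new group at the 4-position of the ring. Among the compounds with values here, no measured pair shows what moving the bromine to the 3-bromophenyl arrangement does, so that part of the change has no precedent here. Compound 4 is therefore expected to show a step of about a 1.6-fold lower number from compound 1 to compound 4 (0.21 log units; within the scatter), a modest lowering, with wide uncertainty. The estimate for compound 4 in this assay is 500 nM, within 150 nM to 1600 nM.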

Compound 4, half-maximal inhibitory concentration: > 4000 nM
Compound 4 ended at the assay's limit; the forecaster's own chance of this, stated with the estimate: 5%; at least 8.0-fold (0.90 log units) between middle value and limit.
By their numbers in this assay, from the lowest: compound 3; then compound 2; then compound 1. At a limit, above all of these: compound 4.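

Going from 4-bromophenyl to 3-bromophenyl on the amide-type nitrogen gives an at least 10-fold higher number from compound 2 to compound 4 (1.00 log units; beyond the scatter), so the same atom placed differently on the ring turns a modest gain into a loss. The change from the starting compound gives an at least 4.9-fold higher number from compound 1 to compound 4 (0.69 log units; beyond the scatter), so 3-bromophenyl is worse than 4-ethylphenyl, not merely less helpful than 4-bromophenyl. The value of compound 4 in this assay is a limit, not a number: the limit of > 4000 nM in this assay, at which 1 of the 4 values shown sits.

Still open, on these data alone, is whether this loss belongs to bromine itself or to any group in that arrangement, a question that 3-methylphenyl or 3-aminophenyl could help answer.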